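Amino-indazole in place of chlorophenyl: trypsin outlook

This account rests on a few compounds, and the source may have more. Where it says the series, first, only, none or still open, it means among the compounds named here.

Compound 1, with structure `Cc1cc(C(=O)Nc2ccc(-c3ccccc3S(N)(=O)=O)cc2)n(-c2cccc(C(N)=O)c2)n1`, gives > 1600 nM in an assay on isolated protein for inhibition of Trypsin (Homo sapiens) (a higher number here means a weaker inhibitor, a lower number a stronger inhibitor), which is a limit of the measurement rather than a number.
Compound 2, with structure `Cc1cc(C(=O)Nc2ccc(-c3ccccc3S(N)(=O)=O)cc2)n(-c2cccc(Cl)c2)n1`, gives > 1600 nM in this assay, again a limit and not a number.

Compound 2 therefore stands at the edge of what this assay can report: its value is a limit only. For the measured compounds named here, the single measured step, a step that the two limits leave unreadable from compound 1 to compound 2, runs between two such limits and cannot be read for size or direction, a point underlined by the limit of > 1600 nM in this assay, at which 2 of the 2 values shown sit.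

The change now followed is 3-amino-2H-indazol-6-yl in place of 3-chlorophenyl on an aromatic nitrogen, giving compound 3 with structure `Cc1cc(C(=O)Nc2ccc(-c3ccccc3S(N)(=O)=O)cc2)n(-c2ccc3c(N)[nH]nc3c2)n1`. No measured step bears on this change; the only step shown touches a different part of the molecule and is itself unreadable. From compound 2 to compound 3 a step of an at least 4.0-fold lower number from compound 2 to compound 3 (0.60 log units; beyond the scatter) is expected, toward stronger inhibition, though this rests on no measured comparison. The estimate for compound 3 in this assay is 400 nM, with a range from 40 nM to 3000 nM.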

Compound 3, inhibition constant: > 1600 nM
Compound 3 ended at the assay's limit (the forecaster's own chance of this, stated with the estimate: 35%); middle value at least 4.0-fold (0.60 log units) from the limit.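

Compound 3, like compound 1 and compound 2, gives only a limit and not a number, so no step among these three compounds can be read for size or direction: the limit of > 1600 nM in this assay, at which 3 of the 3 values shown sit.

The compounds shown leave open how strongly each one inhibits in this assay, and whether changing the group on the aromatic nitrogen alters that inhibition at all.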